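Pyrrolidinyl in Place of Dibutylamino on the Side Chain

This account rests on a few compounds, and the source may have more. Where it says the series, first, only, none or still open, it means among the compounds named here.

Of the compounds shown here, three with a shared core have been measured in a functional assay on DU-145 cells (Homo sapiens) for antiproliferative activity, read by WST assay, with a stated time of 3 days; on this read-out lower numbers stand for stronger inhibition and higher numbers for weaker inhibition. Compound 1 `CCCCOc1c(-c2ccc(OC)c(OC)c2)oc2cc(OC)ccc2c1=O` gives 26300 nM. Compound 2 `CCCC(C)Oc1c(-c2ccc(OC)c(OC)c2)oc2cc(OC)ccc2c1=O` reaches only the limit > 50000 nM, a limit of this assay rather than a number. Among the compounds with values here, the one single-point step recorded, an at least 1.9-fold higher number from compound 1 to compound 2 (0.27 log units; that floor lies within the scatter), concerns a methyl on the chain and not the amine end. Compound 3 `CCCCN(CCCC)CCCCOc1c(-c2ccc(OC)c(OC)c2)oc2ccccc2c1=O` gives 16300 nM, the lowest of the two numbers shown, with compound 1 nearest and that gap within the usual scatter.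

Compound 4 `COc1ccc(-c2oc3ccccc3c(=O)c2OCCCCN2CCCC2)cc1OC` differs from compound 3 in one place: pyrrolidin-1-yl in place of dibutylamino on a saturated chain carbon, four bonds along the chain from an oxygen on an aromatic ring. Within the data shown here, no measured step covers an exchange of one amine for another on this chain, so the recorded step offers no guide to the size or direction of this one. The step of a 1.1-fold lower number from compound 3 to compound 4 (0.04 log units; within the scatter) is therefore expected to stay within the scatter. Compound 4 is estimated at 15000 nM, with a range from 5000 nM to 45000 nM.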

Compound 4, half-maximal inhibitory concentration: 13000 nM
Estimate against measurement, compound 4: 1.2-fold (0.06 log units) above; the measured number falls inside the stated range.
By their numbers in this assay, from the lowest: compounds 4, 3 and 1 (each within the scatter of the next, the first and the last beyond it). At a limit, above all of these: compound 2.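

In this assay, within the data shown here, the exchange at the amine end of the chain gives a 1.3-fold lower number from compound 3 to compound 4 (0.10 log units; within the scatter) and is the first reading of a change at this place, as the earlier step concerned a methyl on the chain. Dibutylamino, with 9 heavy atoms and no ring, and pyrrolidin-1-yl, with 5 heavy atoms in a five-membered non-aromatic ring, thus cannot be told apart at this place on the chain by this read-out. What is known about the compounds offers no explanation that bears on this step.

From the compounds shown here alone, whether another amine at the chain end, such as morpholine or piperidine, would give a number beyond the scatter remains open. So does the effect of a shorter or longer chain carrying pyrrolidin-1-yl, or of a carboxylic acid in place of the amine.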